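Ethynyl replaces phenyl in a series stuck at its limit

The source may report more compounds than this note shows. Statements on the series, on what has been measured and on what is new or still open speak of the compounds shown alone.

In a functional assay on CCRF-CEM cells (Homo sapiens), read by MTT assay, with a stated time of 72 h (on this read-out higher numbers stand for weaker inhibition and lower numbers for stronger inhibition), compound 1 (`CNc1ncnc2c1c(-c1cccs1)cn2[C@@H]1O[C@H](CO)[C@@H](O)[C@H]1O`) carries thiophen-2-yl and gives > 20000 nM as a limit, not a number. Compound 2 (`CNc1ncnc2c1c(-c1ccsc1)cn2[C@@H]1O[C@H](CO)[C@@H](O)[C@H]1O`) carries thiophen-3-yl and likewise gives > 20000 nM as a limit. Compound 3 (`CNc1ncnc2c1c(-c1ccccc1)cn2[C@@H]1O[C@H](CO)[C@@H](O)[C@H]1O`) carries phenyl and gives > 20000 nM as a limit too. Compound 3 thus has no number of its own, and the series shares the limit of > 20000 nM in this assay, at which 3 of the 3 values shown sit, as its only result. Compound 4 (`C#Cc1cn([C@@H]2O[C@H](CO)[C@@H](O)[C@H]2O)c2ncnc(NC)c12`) has ethynyl in place of phenyl on an aromatic carbon and awaits measurement. Within the data shown here, three measured steps bear on this change: a step that the two limits leave unreadable from compound 1 to compound 2 and a step that the two limits leave unreadable from compound 1 to compound 3 and a step that the two limits leave unreadable from compound 2 to compound 3 as the last. None has a readable size, and each swaps one ring for another, whereas ethynyl has no ring. The expected change is an at least 2.0-fold lower number from compound 3 to compound 4 (0.30 log units; that floor lies within the scatter) and it is tentatively expected to point toward stronger inhibition, though another limit is quite possible. For compound 4 the estimate is 10000 nM and the expected range runs from 1000 nM to 20000 nM as its two ends.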

Compound 4, half-maximal inhibitory concentration: > 20000 nM
Compound 4 ended at the assay's limit; the forecaster's own chance of this, stated with the estimate: 55%; middle value at least 2.0-fold (0.30 log units) from the limit.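

Compound 4 also ends at a limit, and none of its steps from compound 1, compound 2 or compound 3 can be read: the limit of > 20000 nM in this assay, at which 4 of the 4 values shown sit. The compounds shown leave open whether any group at this place would give a measurable number in this assay.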